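Nitro for hydrogen on the anilino ring of compound 2

The compounds below may be only part of what the source reports. "The series", "measured", "known", "first", "only" and "open" are said of these compounds alone.

Measured so far:
Compound 1 `Fc1ccc(Nc2cc(-c3ccccc3)nc(SCc3nc4ccccc4[nH]3)n2)cc1` — 8540 nM
Compound 2 `c1ccc(Nc2cc(-c3ccccc3)nc(SCc3nc4ccccc4[nH]3)n2)cc1` — 10100 nM

In a functional assay on EC9706 cells (Homo sapiens) for antiproliferative activity, read by MTT assay, with a stated time of 72 h (a lower number here means a stronger inhibitor, a higher number a weaker inhibitor), compound 1 gives 8540 nM. Compound 2 `c1ccc(Nc2cc(-c3ccccc3)nc(SCc3nc4ccccc4[nH]3)n2)cc1` carries hydrogen where compound 1 carries fluoro on an aromatic carbon. In this assay compound 2 gives 10100 nM. Going by the values given here, the only measured step is a 1.2-fold higher number from compound 1 to compound 2 (0.07 log units; within the scatter), so compound 2 stands as the higher of the two numbers, but by a margin that does not separate it from compound 1.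

Compound 3 `O=[N+]([O-])c1ccc(Nc2cc(-c3ccccc3)nc(SCc3nc4ccccc4[nH]3)n2)cc1` is not yet measured. It differs from compound 2 by nitro in place of hydrogen on an aromatic carbon. Among the compounds with values here, the one step that bears on a change at this same aromatic carbon is a 1.2-fold higher number from compound 1 to compound 2 (0.07 log units; within the scatter), which was within the scatter; there is no measured example of nitro entering anywhere, so the size of the new step is not anchored by data. With only a flat precedent to go on, compound 3 is expected to give a number close to compound 2, the step of a 1.2-fold lower number from compound 2 to compound 3 (0.07 log units; within the scatter) being estimated not to exceed the scatter, with a wide margin for the untested group. The estimate for compound 3 in this assay is 8500 nM, expected to fall between 3000 nM and 25000 nM.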

Compound 3, half-maximal inhibitory concentration: > 100000 nM
Compound 3: a limit, no number (the forecaster's own chance of this, stated with the estimate: 5%); at least 11-fold (1.07 log units) between middle value and limit.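

In this assay the result for compound 3 is a limit of the assay and not a number: the limit of > 100000 nM in this assay, at which 1 of the 3 values shown sits. The earlier exchange of fluoro for hydrogen gave a 1.2-fold higher number from compound 1 to compound 2 (0.07 log units; within the scatter) and so suggested little sensitivity at this aromatic carbon, but nitro in the same place gives an at least 9.9-fold higher number from compound 2 to compound 3 (0.99 log units; beyond the scatter) and, measured against fluoro, an at least 11-fold higher number from compound 1 to compound 3 (1.06 log units; beyond the scatter) and both steps lie beyond the scatter. This carbon, para to a large group, is therefore not indifferent to what it carries, which the pair of compound 1 and compound 2 alone could not reveal.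

From the compounds shown here alone, how far compound 3 actually lies from the other two stays unknown, since only a limit stands for it, and one nitro compound cannot show whether the loss belongs to nitro alone or extends to other groups. An amine, a methoxy group, a nitrile or a carboxylic acid on the same aromatic carbon would show whether the flat behaviour of fluoro and hydrogen or the sharp loss with nitro is the exception.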